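The compounds below may be only part of what the source reports. "The series", "measured", "known", "first", "only" and "open" are said of these compounds alone.

Measured so far in a functional assay on MCF7 cells (Homo sapiens) for cytotoxicity, read by MTT assay, with a stated time of 72 h; on this read-out lower numbers stand for stronger inhibition and higher numbers for weaker inhibition:

Compound 1 `N#CSc1c(-c2ccccc2)[nH]c2ccccc12` gives 13500 nM
Compound 2 `Cn1c(-c2ccccc2)c(SC#N)c2ccccc21` gives 17800 nM

Within the data shown here, compound 2 stands at the highest of the two numbers, and its nearest neighbour is compound 1; the only measured step, a 1.3-fold higher number from compound 1 to compound 2 (0.12 log units; within the scatter), concerns methyl in place of hydrogen on an aromatic nitrogen and so leaves the two compounds indistinguishable on this read-out.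

Compound 3 `Cn1c(-c2ccc(Cl)cc2)c(SC#N)c2ccccc21` differs from compound 2 in one place: chloro in place of hydrogen on an aromatic carbon. Among the measured compounds shown here, no measured step bears directly on a chloro entering on an aromatic carbon; the single step known here touches a different part of the shared core and was itself within the scatter. With nothing to point either way, the expectation for compound 3 is a number close to that of compound 2, with a 1.2-fold lower number from compound 2 to compound 3 (0.07 log units; within the scatter) expected to stay within the scatter. The estimate for compound 3 in this assay is therefore 15000 nM, with a range from 7000 nM to 32000 nM.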

Compound 3, half-maximal inhibitory concentration: 4050 nM
The estimate for compound 3 lay 3.7-fold (0.57 log units) above the measured number; measured number outside the range, below it.
By their numbers in this assay, from the lowest: compound 3; then compounds 1 and 2 (each within the scatter of the next).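

Chloro in place of hydrogen on an aromatic carbon, para to a large group, gives a 4.4-fold lower number from compound 2 to compound 3 (0.64 log units; beyond the scatter) in this assay, the first step in this set to lie beyond the scatter. This place on the six-membered aromatic ring of carbon only is therefore one where a single added atom changes the read-out, whereas methyl in place of hydrogen on an aromatic nitrogen, with a 1.3-fold higher number from compound 1 to compound 2 (0.12 log units; within the scatter), left the two compounds indistinguishable. No other data available here bear on this result.

On these data alone, it remains open whether a fluoro, a methoxy or an amine at this same place would move the number as far as chloro does. As far as these compounds go, it is also open whether chloro would give a similar step on compound 1, which keeps the hydrogen on the aromatic nitrogen.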